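Opening a Ring on the Chain: Cytotoxicity Outlook

The compounds below may be only part of what the source reports. "The series", "measured", "known", "first", "only" and "open" are said of these compounds alone.

Compound 1, `C=C[C@@](C)(/C=C/c1ccc(O)cc1)CCC1OC1(C)C`, was tested in an ADME assay on BJ cells (Homo sapiens) for cytotoxicity, with a stated time of 72 h; on this read-out higher numbers stand for an effect only at larger amounts of compound and lower numbers for an effect already at smaller amounts. In this assay compound 1 gives only a limit, > 36600 nM, and not a number. Compound 2, `C=C[C@@](C)(/C=C/c1ccc(O)cc1)CC/C=C/C(=O)OCc1ccccc1`, was run in this assay as well. Compound 2 likewise gives only a limit, > 36600 nM. Taken together this is the limit of > 36600 nM in this assay, at which 2 of the 2 values shown sit, so compound 1 stands at the edge of what this assay can report, with its one companion beside it, and no measured step separates the two.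

Compound 3, `C=C[C@@](C)(/C=C/c1ccc(O)cc1)CC/C=C(\C)CO`, has not yet been measured in this assay. It differs from compound 1 in one place: 2-(hydroxymethyl)prop-1-en-1-yl in place of 3,3-dimethyloxiran-2-yl on a saturated chain carbon, three bonds along the chain from two double-bonded chain carbons. Among the measured compounds shown here, no measured step between compounds exists here to lean on, so the step this estimate means, a step that the limit leaves unreadable from compound 1 to compound 3, is expected to be none beyond the scatter. Compound 3 is therefore expected to give about 40000 nM in this assay, with a range from 20000 nM to 100000 nM, and most likely again only a limit rather than a number.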

Compound 3, half-maximal effective concentration: > 36600 nM
Compound 3: no number, only a limit; the forecaster's own chance of this, stated with the estimate: 85%; the middle value is on the limit's open side.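

Compound 3 gives only a limit in this assay, > 36600 nM. Among the compounds shown here, compound 1 also gives only a limit, so no step from compound 1 to compound 3 can be read: the limit of > 36600 nM in this assay, at which 3 of the 3 values shown sit. The compounds shown leave open where each would take effect on these cells, and whether replacing 3,3-dimethyloxiran-2-yl with 2-(hydroxymethyl)prop-1-en-1-yl changes that at all.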